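Fluoro for Methoxy: From Compound 1 to Compound 4

This account rests on a few compounds, and the source may have more. Where it says the series, first, only, none or still open, it means among the compounds named here.

In a functional assay on A549 cells (Homo sapiens) for inhibition, read by MTT assay, with a stated time of 24 h (on this read-out lower numbers stand for stronger inhibition and higher numbers for weaker inhibition), compound 1 `CCOC(=O)C1=Cc2ccccc2OC1(OCc1cc(-c2ccc(OC)cc2)no1)C(F)(F)F` reports only a limit, > 150000 nM; this is the limit of > 150000 nM in this assay, at which 1 of the 3 values shown sits. Compound 3 `COc1ccc(-c2cc(COC3(C(F)(F)F)Oc4ccccc4C=C3C(=O)O)on2)cc1` gives 36200 nM in this assay, and compound 2 `CCOC(=O)C1=Cc2ccccc2OC1(OCc1cn(CC(=O)Nc2ccc(C)cc2)nn1)C(F)(F)F` gives 54300 nM. Within the data shown here, the only measured step between close neighbours, an at least 4.1-fold lower number from compound 1 to compound 3 (0.61 log units; beyond the scatter), concerns the ester and not the aromatic substituent, so no measured step bears on the change that leads to compound 4 `CCOC(=O)C1=Cc2ccccc2OC1(OCc1cc(-c2ccc(F)cc2)no1)C(F)(F)F`, namely (fluoro in place of methoxy on an aromatic carbon). Because compound 1 sits at the limit, the step to compound 4 is expected to show no movement beyond the scatter, which is what an at least 1.0-fold lower number from compound 1 to compound 4 (0.02 log units; that floor lies within the scatter) expresses. Compound 4 is therefore estimated near 140000 nM, within 50000 nM to 400000 nM, and this assay may well again return only a limit.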

Compound 4, half-maximal inhibitory concentration: 35500 nM
Estimate against measurement, compound 4: 3.9-fold (0.60 log units) above; measured number outside the range, below it.
By their numbers in this assay, from the lowest: compounds 4, 3 and 2 (each within the scatter of the next). At a limit, above all of these: compound 1.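

In this assay, fluoro in place of methoxy on an aromatic carbon, with the ethyl ester kept, gives an at least 4.2-fold lower number from compound 1 to compound 4 (0.62 log units; beyond the scatter). Among these compounds, this shows that the aromatic substituent, which no earlier step touched, also bears on the read-out, and not only the ester. That step is only a floor, because compound 1 reports a limit and not a number: the limit of > 150000 nM in this assay, at which 1 of the 4 values shown sits.

The compounds shown leave open whether the fluoro itself or the loss of methoxy matters, and how a chloro or an amine would read at this place. Going by these compounds, it also remains open whether a carboxylic acid in place of the ester would add to the fluoro change.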